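The source may report more compounds than this note shows. Statements on the series, on what has been measured and on what is new or still open speak of the compounds shown alone.

Of the compounds shown here, three built on a shared core have been measured in a functional assay on U-87MG ATCC cells for antiproliferative activity against U-87 MG (Homo sapiens), with a stated time of 5 days; on this read-out higher numbers stand for an effect only at larger amounts of compound and lower numbers for an effect already at smaller amounts. Compound 1 `Nc1nc2cc(-c3nn(CC4OCCO4)c4ncnc(N)c34)ccc2o1` gives 100 nM in this assay. Compound 2 `Nc1nc2cc(-c3nn(CC4CCCO4)c4ncnc(N)c34)ccc2o1` gives 100 nM in this assay, and compound 3 `CCOC(Cn1nc(-c2ccc3oc(N)nc3c2)c2c(N)ncnc21)OCC` gives 100 nM in this assay. Compound 2 thus stands level with compounds 1 and 3 at the digits shown; compound 1 is its nearest neighbour and compound 3 its furthest, yet neither gap rises above the scatter. The three steps among them read no change at the digits printed from compound 1 to compound 2 (within the scatter), no change at the digits printed from compound 1 to compound 3 (within the scatter) and no change at the digits printed from compound 2 to compound 3 (within the scatter).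

Compound 4 `COC(Cn1nc(-c2ccc3oc(N)nc3c2)c2c(N)ncnc21)OC` has not yet been measured. It differs from compound 2 by dimethoxymethyl in place of oxolan-2-yl on a saturated chain carbon bound to an aromatic nitrogen. The step from compound 2 to compound 3 bears most directly on this change, since it likewise put an open chain, diethoxymethyl, in place of oxolan-2-yl on that same carbon and produced no movement beyond the scatter; the steps from compound 1 to compound 2 and from compound 1 to compound 3 show the same flatness across all three groups tried there. On that basis compound 4 is expected to sit in this assay at 100 nM, within a range from 50 nM to 200 nM. The expected step is therefore no change at the digits printed from compound 2 to compound 4 (within the scatter), none beyond the scatter.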

Compound 4, half-maximal effective concentration: 100 nM
Compound 4: the middle estimate sits on the measured number at the digits printed; low and high end bracket the measured number.
By their numbers in this assay, from the lowest: compounds 1, 2, 3 and 4 (each within the scatter of the next).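

In this assay, dimethoxymethyl in place of oxolan-2-yl gives no change at the digits printed from compound 2 to compound 4 (within the scatter) on the saturated chain carbon bound to an aromatic nitrogen, so this swap, which keeps the 5 heavy atoms, opens the ring and goes from 1 hydrogen-bond acceptor to 2, leaves the read-out flat. The earlier compounds had not shown a change within the open chains, and dimethoxymethyl in place of diethoxymethyl now gives no change at the digits printed from compound 3 to compound 4 (within the scatter) in the same place. With dimethoxymethyl in place of 1,3-dioxolan-2-yl reading no change at the digits printed from compound 1 to compound 4 (within the scatter) as well, all four groups shown at this place stand level, and none of the four compounds goes against that.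

Whether the level holds for an amine, a carboxylic acid or a longer chain on this carbon stays open, since every group shown here carries ring or chain oxygen. Nothing at hand says why these four groups read alike.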